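The source may hold more compounds than are shown below. What is called first, only, known or untested is meant among the compounds shown, and "the series" means these compounds.

In an assay on isolated protein for activation of cGMP-dependent protein kinase 1 (Homo sapiens), read by ADP-Glo, with stated times of 30 min and 2 h (on this read-out lower numbers stand for an effect already at smaller amounts and higher numbers for an effect only at larger amounts of compound), compound 1, with the structure `COc1cccc([C@@H](CO)O[C@H]2CCCN(Cc3ccc(C(=O)O)cc3C)[C@H]2c2ccccc2)c1`, gives only the assay limit > 200000 nM. Compound 2, with the structure `Cc1cc(C(=O)O)ccc1CN1CCC[C@H](O[C@H](CO)c2ccccc2)[C@@H]1c1ccccc1`, likewise gives in this assay only the limit > 200000 nM. Compound 3, with the structure `Cc1cc(C(=O)O)ccc1CN1CCC[C@H](O[C@H](CO)c2cc(F)cc(F)c2)[C@@H]1c1ccccc1`, also reaches in this assay only the limit > 200000 nM, so where compound 3 stands among the numbers shown is known only as a limit, not as a number. The three steps between these compounds, a step that the two limits leave unreadable from compound 1 to compound 2, a step that the two limits leave unreadable from compound 1 to compound 3 and a step that the two limits leave unreadable from compound 2 to compound 3, cannot be read in size, since (the limit of > 200000 nM in this assay, at which 3 of the 3 values shown sit).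

Compound 4, with the structure `Cc1cc(C(=O)O)ccc1CN1CCC[C@H](O[C@H](CF)c2cc(Cl)cc(Cl)c2)[C@@H]1c1ccccc1`, differs from compound 3 by a group of 11 heavy atoms (8 carbon, 1 fluorine, 2 chlorine; one six-membered aromatic ring of carbon only) in place of a group of 11 heavy atoms (8 carbon, 1 oxygen, 2 fluorine; one six-membered aromatic ring of carbon only), on an oxygen on a saturated carbon. All steps that bear on this change are unreadable, so no direction can be drawn from them; the expectation rests only on the fact that every measured compound sits at the limit. Compound 4 is therefore expected to give in this assay about 200000 nM, within a range from 50000 nM to 1000000 nM, most likely again as a limit. The step from compound 3 to compound 4 is thus estimated as a number no higher from compound 3 to compound 4 (the limit leaves the size open).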

Compound 4, half-maximal effective concentration: 20000 nM
Beside the measured number, compound 4's estimate is 10-fold (1.00 log units) above it, and the stated range ends above it.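

In this assay, among the compounds shown here, the group on the oxygen proves able to move the read-out: its change gives an at least 10-fold lower number from compound 3 to compound 4 (1.00 log units; beyond the scatter), along with an at least 10-fold lower number from compound 2 to compound 4 (1.00 log units; beyond the scatter) and an at least 10-fold lower number from compound 1 to compound 4 (1.00 log units; beyond the scatter), whereas the steps among the earlier compounds cannot be read. Compound 4 is the only compound shown with a measured number, and these steps give only a minimum size because the other compounds stop at a limit: the limit of > 200000 nM in this assay, at which 3 of the 4 values shown sit. The change has two parts, with fluorine on the chain where compound 3 carries a hydroxyl, and chlorine on the aromatic ring where compound 3 carries fluorine.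

The compounds shown do not separate these two parts, so it stays open which one carries the step. As far as these compounds go, it also stays open whether bromine on the ring or an amine on the chain would give a similar number.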